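A few compounds are considered here, and "the series" means these few. Any claim that something is new, unique, unknown or untested is made for them only; others in the source may bear on it.

Working notes on the acylguanidine series.

Two compounds have numbers in an in vitro assay on Sf9 cells for agonist activity at histamine H2 receptor (Homo sapiens), read by scintillation counting; a higher number here means that more compound is needed for the effect, a lower number that less compound is needed. Compound 1 `CCC(=O)/N=C(\N)NCCCc1c[nH]cn1` gives 372 nM in this assay. Compound 2 `CN(CCC(=O)/N=C(\N)NCCCc1c[nH]cn1)C(=O)c1cc2ccccc2[nH]1` gives 347 nM in this assay. Compound 1 holds the higher of the two numbers, and compound 2 sits nearest to it; the gap between the two values lies within the scatter of repeated measurements, so the two compounds read as equivalent on the numbers shown, and no step between them is counted.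

Compound 3 `CC(C)C(=O)/N=C(\N)NCCCc1c[nH]cn1` has not yet been measured in this assay. It differs from compound 1 by methyl in place of hydrogen on a saturated chain carbon bound to a carbonyl carbon and a saturated chain carbon, so that the acyl group reads as isopropylcarbonyl where compound 1 carries propanoyl. Among the measured compounds shown here, no measured pair shows this kind of change, so there is no reference step to lean on. The expectation is a step from compound 1 to compound 3 of a 1.1-fold lower number from compound 1 to compound 3 (0.03 log units; within the scatter), which is taken to stay within the scatter. For compound 3 the estimated value in this assay is 350 nM, with a range from 150 nM to 900 nM.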

Compound 3, half-maximal effective concentration: 110 nM
Compound 3: the middle estimate sits 3.2-fold (0.50 log units) above what was measured, and the stated range ends above it.
By their numbers in this assay, from the lowest: compound 3; then compounds 2 and 1 (each within the scatter of the next).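

The acyl end of the core of compound 1 responds in this assay to a single small change: methyl in place of hydrogen on a saturated chain carbon bound to a carbonyl carbon and a saturated chain carbon gives a 3.4-fold lower number from compound 1 to compound 3 (0.53 log units; beyond the scatter) and this modest step lies beyond the scatter. The earlier compounds shown here offered two values within the scatter of each other and no pair differing in one place, so they left unshown that this position can move the number at all; the change from propanoyl to isopropylcarbonyl shows that it can, towards less compound needed. No measured property of either compound bears on this step, so the data offer no account of it.

As far as these compounds go, whether the step belongs to the branched shape of isopropylcarbonyl or merely to the added methyl stays open, as one pair cannot separate the two, and a butanoyl or cyclopropylcarbonyl group in the same place would be needed to tell. Also open, from the compounds shown here alone, is whether the same methyl would give a similar step on the longer acyl chain of compound 2.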